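Removing the butyl group from compound 1

A few compounds are considered here, and "the series" means these few. Any claim that something is new, unique, unknown or untested is made for them only; others in the source may bear on it.

Measured so far in a functional assay on HCT-116 cells (Homo sapiens) for antiproliferative activity, read by MTT assay, with a stated time of 48 h; on this read-out higher numbers stand for weaker inhibition and lower numbers for stronger inhibition:
- Compound 1 `CCCCC(CCO)n1cnc2c(Cl)nc(F)nc21` gives 13500 nM
- Compound 2 `CCCCC(CCO)n1cnc2c(Cl)nc(Cl)nc21` gives 15500 nM
- Compound 3 `CC(C)(C)[Si](C)(C)OCC(CCO)n1cnc2c(Cl)nc(F)nc21` gives 7780 nM

Compound 1 stands within the scatter of both other numbers. The two steps are a 1.1-fold higher number from compound 1 to compound 2 (0.06 log units; within the scatter) and a 1.7-fold lower number from compound 1 to compound 3 (0.24 log units; within the scatter). Compound 4 `OCCCn1cnc2c(Cl)nc(F)nc21` has not yet been measured. It departs from compound 1 as follows: hydrogen in place of butyl on a saturated chain carbon bound to an aromatic nitrogen and a saturated chain carbon, with hydrogen in place of butyl on a saturated chain carbon bound to an aromatic nitrogen and a saturated chain carbon.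

The step to compound 2 concerns an aromatic carbon, so it says little here. The step to compound 3 alters the same side chain and stays within the scatter, but it swaps one group for a larger one rather than removing it. For the measured compounds named here, no measured compound shows the loss of the butyl group, so the guidance is weak. A modest move towards a higher number in this assay is expected, and it may not clear the scatter. The expected step is a 1.5-fold higher number from compound 1 to compound 4 (0.17 log units; within the scatter). The estimate for compound 4 is 20000 nM, with an expected range from 8000 nM to 60000 nM.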

Compound 4, half-maximal inhibitory concentration: 39800 nM
Compound 4: middle estimate off by 2.0-fold (0.30 log units), on the low side; low and high end bracket the measured number.
By their numbers in this assay, from the lowest: compounds 3, 1 and 2 (each within the scatter of the next); then compound 4.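

In this assay, hydrogen in place of butyl on a saturated chain carbon bound to an aromatic nitrogen and a saturated chain carbon gives a 2.9-fold higher number from compound 1 to compound 4 (0.47 log units; beyond the scatter) and is the only step shown that lies beyond the scatter. For the compounds shown here, the earlier steps, chloro for fluoro on an aromatic carbon and a larger group replacing part of the butyl chain, had stayed within it, so this result is the first sign that the number responds to a change on this side chain: losing the butyl group altogether costs activity, whereas exchanging part of it did not measurably do so.

The compounds shown leave open whether a methyl group, an ethyl group, a longer chain such as hexyl or a phenyl ring at this carbon would keep the number of compound 1 or lower it further. They also leave open why the loss of butyl raises the number, and no supporting measurement bears on that question.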